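Compound 3 as a Halogenated Variant of Compound 2

A few compounds are considered here, and "the series" means these few. Any claim that something is new, unique, unknown or untested is made for them only; others in the source may bear on it.

Compound 1 `CC1CCC(=NNc2ccccc2)c2ncc(C(=O)NO)c(=O)n21` and compound 2 `Cc1cc(C)cc(NN=C2CCC(C)n3c2ncc(C(=O)O)c3=O)c1` were both examined in a functional assay on the whole organism with Rattus norvegicus as the target; a lower number here means that less compound is needed, a higher number that more compound is needed for the effect. In this assay compound 1 reaches only a limit, > 100 umol/kg, and not a number (the limit of > 100 umol/kg in this assay, at which 1 of the 2 values shown sits). Among the compounds with values here, compound 2 likewise stands at a limit in this assay, > 320 umol/kg, which is the only information on where it lies (the limit of > 320 umol/kg in this assay, at which 1 of the 2 values shown sits). Compound 3 `CC1CCC(=NNc2c(Cl)cccc2Cl)c2ncc(C(=O)O)c(=O)n21` differs from compound 2 by 2,6-dichlorophenyl in place of 3,5-dimethylphenyl on an amine nitrogen. Within the data shown here, since no measured step exists, nothing beyond the usual scatter is expected in this assay. Compound 3 is therefore estimated at 320 umol/kg, between 100 umol/kg and 1000 umol/kg. The expected step of a number no higher from compound 2 to compound 3 (the limit leaves the size open) is essentially none.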

Compound 3, dose for 50% inhibition: > 100 umol/kg
Compound 3: a limit, no number; the forecaster's own chance of this, stated with the estimate: 80%; the middle value is on the limit's open side.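

In this assay compound 3 gives only a limit, > 100 umol/kg. Compound 2 also gives only a limit, > 320 umol/kg. Within the data shown here, no step between compound 2 and compound 3 can be read. The compounds shown leave open what dose any of them needs for the effect.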